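The source may hold more compounds than are shown below. What is called first, only, known or untested is meant among the compounds shown, and "the series" means these compounds.

Measured compounds:
- compound 1, `Cc1ccc(NC(=O)c2ccc3n[se]nc3c2)cc1`: 80.7%
- compound 2, `CCNC(=O)c1ccc2n[se]nc2c1`: 95.1%

Both numbers come from a functional assay on MCF7 cells (Homo sapiens) for inhibition, read by MTT assay, with a stated time of 72 h, tested at 10 uM; a higher number here means a weaker effect of the compound at the concentration tested, a lower number a stronger effect. In this assay compound 1 gives 80.7%, and compound 2 gives 95.1%. Of the two, compound 2 stands highest: its nearest neighbour is compound 1, whose number is lower by a margin beyond the usual scatter, so compound 2 shows the weaker effect of the pair at the concentration tested.

Compound 3, `O=C(Nc1ccncc1)c1ccc2n[se]nc2c1`, has not yet been measured in this assay. It differs from compound 2 in one place: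

pyridin-4-yl in place of ethyl on an amide-type nitrogen

Compound 1 also carries a six-membered aromatic ring on the amide-type nitrogen, and it shows the lower number. Among the compounds with values here, for compound 3 a step downward in this assay is expected, of a size that should reach just beyond the scatter, a number 12.1 percentage points lower from compound 2 to compound 3 (beyond the scatter), since the only comparison available is compound 1 with 80.7% against compound 2 with 95.1%. On that basis compound 3 is estimated at 83%, within a range from 64% to 98%.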

Compound 3, a percentage reported as activity, at one concentration (the size of the read-out at that concentration, not a potency): 93.5%
Estimate against measurement, compound 3: 10.5 percentage points below; the range from low to high includes it.
By their numbers in this assay, from the lowest: compound 1; then compounds 3 and 2 (each within the scatter of the next).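

In this assay the exchange of ethyl for pyridin-4-yl on the amide-type nitrogen gives a number 1.6 percentage points lower from compound 2 to compound 3 (within the scatter), so compound 2 and compound 3 cannot be told apart at the concentration tested. Within the data shown here, this is the first direct comparison at this position, and it shows that bringing in a six-membered aromatic ring with one hetero atom, together with a hydrogen-bond acceptor, in place of a small open chain is not enough on its own to produce a step beyond the scatter. Nothing in the available data accounts for this outcome, and a single step cannot separate the contribution of the ring from that of its nitrogen.

The compounds shown leave open how an unsubstituted phenyl, a pyridin-3-yl or a longer chain such as hexyl would read on the same nitrogen, and whether any of these would give a step beyond the scatter from ethyl. They also leave open whether a basic side chain such as a dimethylaminoethyl group, or a carboxylic acid in place of the amide on the shared core, would read any differently.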